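Hydrazone series on a triazolylpyridyl ether core: aryl swaps and a triazole change

This account rests on a few compounds, and the source may have more. Where it says the series, first, only, none or still open, it means among the compounds named here.

Three compounds carry the same core and differ only in the aryl ring on the carbon with a double bond to nitrogen. In a functional assay on MKN-45 cells (Homo sapiens) for cytotoxicity, read by MTT assay, with a stated time of 72 h (on this read-out higher numbers stand for weaker inhibition and lower numbers for stronger inhibition), compound 1 `CN(C)CCn1cnnc1-c1cc(Oc2ccc(NC(=O)N/N=C/c3ccc(Cl)cc3Cl)cc2F)ccn1` gives 750 nM and compound 2 `CN(C)CCn1cnnc1-c1cc(Oc2ccc(NC(=O)N/N=C/c3c[nH]c4ccccc34)cc2F)ccn1` gives 790 nM; the change a 1.1-fold higher number from compound 1 to compound 2 (0.02 log units; within the scatter) stays within the scatter. Compound 3 `CN(C)CCn1cnnc1-c1cc(Oc2ccc(NC(=O)N/N=C/c3ccccc3)cc2F)ccn1` gives 2730 nM, the highest of the three numbers; the steps of a 3.6-fold higher number from compound 1 to compound 3 (0.56 log units; beyond the scatter) and a 3.5-fold higher number from compound 2 to compound 3 (0.54 log units; beyond the scatter) are modest but beyond the scatter. Compound 4 `Cn1ncnc1-c1cc(Oc2ccc(NC(=O)N/N=C/c3ccccc3)cc2F)ccn1` changes a different part of the core: 1-methyl-1H-1,2,4-triazol-5-yl in place of 4-(2-(dimethylamino)ethyl)-4H-1,2,4-triazol-3-yl on an aromatic carbon. Within the data shown here, no measured step touches this position, so nothing predicts its size or direction. The number for compound 4 is therefore expected to stay close to that of compound 3, estimated at 2700 nM (range 900 nM to 8000 nM), a step of a 1.0-fold lower number from compound 3 to compound 4 (0.00 log units; within the scatter) expected to lie within the scatter.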

Compound 4, half-maximal inhibitory concentration: > 100000 nM
Compound 4: no number, only a limit; the forecaster's own chance of this, stated with the estimate: 5%; at least 37-fold (1.56 log units) between middle value and limit.
By their numbers in this assay, from the lowest: compounds 1 and 2 (each within the scatter of the next); then compound 3. At a limit, above all of these: compound 4.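

The triazole position tolerates change far less than the aryl position: in this assay, 1-methyl-1H-1,2,4-triazol-5-yl in place of 4-(2-(dimethylamino)ethyl)-4H-1,2,4-triazol-3-yl gives an at least 36-fold higher number from compound 3 to compound 4 (1.56 log units; beyond the scatter), larger than any aryl swap in the series. The value of compound 4 is a limit and not a number: the limit of > 100000 nM in this assay, at which 1 of the 4 values shown sits.

This swap removes the dimethylamino group and the ethyl chain and also alters the triazole substitution, and the compounds shown do not separate these changes. Open, as far as these compounds go, is whether a morpholine or a primary amine at the end of the chain would keep the cytotoxicity, and whether the same swap has a similar effect with 2,4-dichlorophenyl or 1H-indol-3-yl on the hydrazone.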